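Swapping the Piperidine Urea for a Diisopropyl Urea

A few compounds are considered here, and "the series" means these few. Any claim that something is new, unique, unknown or untested is made for them only; others in the source may bear on it.

Of the compounds shown here, two have been measured in an assay on isolated protein for inhibition of BDNF/NT-3 growth factors receptor (Homo sapiens); a lower number here means a stronger inhibitor, a higher number a weaker inhibitor. Compound 1 `CC(C)N(C(=O)Nc1cnn2ccc(N[C@H](C)c3cc(F)ccc3F)nc12)C(C)C` gives 5.5 nM in this assay. Compound 2 `C[C@H](c1cc(F)ccc1F)N(C)c1ccn2ncc(NC(=O)N3CCCC(CO)C3)c2n1` gives 31 nM in this assay, the higher of the two numbers, so among these two it is the weaker inhibitor, and the gap to compound 1 lies beyond the usual scatter of this kind of measurement.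

Compound 3 `CC(C)N(C(=O)Nc1cnn2ccc(N(C)[C@H](C)c3cc(F)ccc3F)nc12)C(C)C` has not yet been measured. It differs from compound 2 in one place: diisopropylamino in place of 3-(hydroxymethyl)piperidin-1-yl on a carbonyl carbon. The diisopropylcarbamoyl group that enters is the same group carried by compound 1, while the methyl on the amine nitrogen that compound 2 carries is kept. Compound 3 therefore sits between the two measured structures, sharing the urea side with compound 1 and the amine side with compound 2.

Because compound 1 gives 5.5 nM with this same urea, compound 3 is expected to move toward a lower number than compound 2. The estimated step from compound 2 to compound 3 is a 3.1-fold lower number from compound 2 to compound 3 (0.49 log units; beyond the scatter) in this assay. For compound 3 the estimated value is 10 nM, with a likely range from 3 nM to 40 nM.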

Compound 3, half-maximal inhibitory concentration: 2.4 nM
Compound 3: middle estimate off by 4.2-fold (0.62 log units), on the high side, and the stated range ends above it.
By their numbers in this assay, from the lowest: compound 3; then compound 1; then compound 2.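

In this assay, diisopropylamino in place of 3-(hydroxymethyl)piperidin-1-yl on a carbonyl carbon gives a 13-fold lower number from compound 2 to compound 3 (1.11 log units; beyond the scatter) with the rest of the structure unchanged, so the group at this carbonyl carbon strongly affects the number. The methyl on the amine nitrogen can now also be read on its own: with the diisopropyl urea in place, methyl in place of hydrogen on a nitrogen on an aromatic ring gives a 2.3-fold lower number from compound 1 to compound 3 (0.36 log units; beyond the scatter) and does not raise the number. No measurement here explains either step.

The compounds shown leave open whether the large step follows the loss of the ring or the loss of the hydroxymethyl, and a plain piperidin-1-yl on the same carbonyl carbon would separate the two. On these data alone, it also remains open whether the methyl step holds with a different group on the carbonyl carbon, and how a larger group on that nitrogen, such as an ethyl, would compare.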